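Replacing the N-methyl of compound 3 with a 4-methoxyphenyl group

The source may hold more compounds than are shown below. What is called first, only, known or untested is meant among the compounds shown, and "the series" means these compounds.

Measured so far:
compound 1 `CCCCc1ccc2c(c1)C(=O)C(=O)N2` with > 10000 nM
compound 2 `Cc1ccc(-c2ccc3c(c2)C(=O)C(=O)N3)cc1` with 6000 nM
compound 3 `COc1ccc(-c2ccc3c(c2)C(=O)C(=O)N3C)cc1` with 6670 nM

In a functional assay on HepG2 cells (Homo sapiens) for antiproliferative activity, read by MTT assay, with a stated time of 48 h (on this read-out higher numbers stand for weaker inhibition and lower numbers for stronger inhibition), compound 1 gives only a limit, > 10000 nM, and not a number (the limit of > 10000 nM in this assay, at which 1 of the 3 values shown sits). Of the two numbers that exist, compound 3 `COc1ccc(-c2ccc3c(c2)C(=O)C(=O)N3C)cc1` has the higher one, yet compound 2 with 6000 nM sits within the scatter of it, so the two cannot be told apart. Compound 4 `COc1ccc(-c2ccc3c(c2)C(=O)C(=O)N3c2ccc(OC)cc2)cc1` has not yet been measured in this assay. It differs from compound 3 by one change: 4-methoxyphenyl in place of methyl on an amide-type nitrogen in a ring. Within the data shown here, no measured pair in this set shows what such a change does on an amide-type nitrogen in a ring, so no step can be borrowed from the data. The expected step of a 1.7-fold lower number from compound 3 to compound 4 (0.22 log units; within the scatter) is therefore set small, leaning towards a lower number, but with a range that covers no change beyond the scatter. For compound 4 the estimate in this assay is 4000 nM, between 1000 nM and 15000 nM.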

Compound 4, half-maximal inhibitory concentration: > 10000 nM
Compound 4 ended at the assay's limit; the forecaster's own chance of this, stated with the estimate: 25%; middle value at least 2.5-fold (0.39 log units) away from the limit.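

In this assay, 4-methoxyphenyl in place of methyl on an amide-type nitrogen in a ring gives an at least 1.4-fold higher number from compound 3 to compound 4 (0.17 log units; that floor lies within the scatter). Among these compounds, this is the first reading of a change at this position, and it shows no sign of stronger inhibition, although its floor alone does not establish a loss. The value of compound 4 is a limit of the assay and not a number, so the true size of the step cannot be read, and this compound joins the values that sit at that limit: the limit of > 10000 nM in this assay, at which 2 of the 4 values shown sit.

On these data alone, whether a benzyl group or a short chain ending in an amine on this nitrogen would give a lower number than compound 3 remains open. The compounds shown also leave open whether a carboxylic acid on the added phenyl ring would alter the outcome.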